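The compounds below may be only part of what the source reports. "The series", "measured", "known", "first", "only" and "open" are said of these compounds alone.

For the measured compounds named here, compound 3 `COC(=O)[C@@]1(C)CCC=C2[C@@H]1CC[C@@H](C)[C@]2(C)Cc1c[nH]c2c(C)cccc12` sits second highest of the three numbers so far: in a functional assay on SW1573 cells (Homo sapiens) for inhibition, read by sulforhodamine B assay, with a stated time of 48 h (on this read-out higher numbers stand for weaker inhibition of growth and lower numbers for stronger inhibition of growth), compound 3 gives 7800 nM. Its nearest neighbour is compound 1 `COC(=O)[C@@]1(C)CCC=C2[C@@H]1CC[C@@H](C)[C@]2(C)Cc1c[nH]c2ccccc12`, for which this assay gives 7300 nM, the step of a 1.1-fold higher number from compound 1 to compound 3 (0.03 log units; within the scatter). Compound 2 `COC(=O)[C@@]1(C)CCC=C2[C@@H]1CC[C@@H](C)[C@]2(C)Cc1c[nH]c2ccc(C)cc12` gives 15000 nM in this assay; between compound 2 and compound 3 the two values lie within the usual scatter of each other.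

Compound 4 `COC(=O)[C@@]1(C)CCC=C2[C@@H]1CC[C@@H](C)[C@]2(C)Cc1c[nH]c2c(Br)cccc12` follows from compound 3 by the change (bromo in place of methyl on an aromatic carbon). The measured steps that bear on it are both methyl-for-hydrogen replacements on an aromatic carbon: a 2.1-fold higher number from compound 1 to compound 2 (0.31 log units; beyond the scatter) and a 1.1-fold higher number from compound 1 to compound 3 (0.03 log units; within the scatter). Going by the values given here, neither step exchanges methyl for bromo, and no measured pair does, so the closest guide is that a single small substituent at this position shifted the number little in either direction. The step of a 1.0-fold higher number from compound 3 to compound 4 (0.01 log units; within the scatter) is therefore expected to stay within the scatter. For compound 4 the estimate in this assay is 8000 nM, with a range from 3500 nM to 18000 nM.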

Compound 4, concentration for 50% growth inhibition: 14000 nM
The estimate for compound 4 lay 1.8-fold (0.24 log units) below the measured number; the range from low to high includes it.
By their numbers in this assay, from the lowest: compounds 1, 3, 4 and 2 (each within the scatter of the next, the first and the last beyond it).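

At this position, ortho to a fused ring, the series now holds bromo as well as methyl. In this assay, for the compounds shown here, the exchange of methyl for bromo gives a 1.8-fold higher number from compound 3 to compound 4 (0.25 log units; within the scatter), and the exchange of hydrogen for bromo gives a 1.9-fold higher number from compound 1 to compound 4 (0.28 log units; within the scatter), so hydrogen, methyl and bromo cannot be told apart here on this read-out, a result the earlier compounds showed for methyl alone. No measurement on hand speaks to what lies behind these numbers.

From the compounds shown here alone, whether an amine, a carboxylic acid or a longer chain at this position would also stay within the scatter of compound 1 remains open. Also open, going by these compounds, is whether bromo, placed where compound 2 carries its methyl, would give a step beyond the scatter, as that methyl does.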